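This account rests on a few compounds, and the source may have more. Where it says the series, first, only, none or still open, it means among the compounds named here.

Compound 1 `COc1ccc(Cc2nnc3n2NC(c2ccco2)S3)cc1OC` gives 21.1% in a functional assay on the whole organism (strain Wistar Albino) for inhibition, with Rattus norvegicus as the target, read by paw edema, with a stated time of 3 h, at a dose of 20 mg/kg (a higher number here means more inhibition at the dose given (going by the name of the read-out), a lower number less inhibition), the lower of the two numbers shown, though compound 2 `Cc1occc1-c1nnc2n1NC(c1ccc([N+](=O)[O-])o1)S2` at 22.8% in this assay sits within the usual scatter of it, so no order between the two can be read. Compound 3 `COc1ccc(Cc2nnc3n2NC(c2ccc[nH]2)S3)cc1OC` differs from compound 1 by 1H-pyrrol-2-yl in place of furan-2-yl on a saturated ring carbon. Going by the values given here, no step between measured compounds is available for this kind of change, so the expected step in this assay is small, in no fixed direction, and not beyond the scatter. Compound 3 is expected to give 22%, between 12% and 33%, an expected change of a number 0.9 percentage points higher from compound 1 to compound 3 (within the scatter).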

Compound 3, a percentage reported as inhibition, in the whole organism at one dose (the size of the read-out at that dose, not a potency): 17.7%
Estimate against measurement, compound 3: 4.3 percentage points above; measured number inside the range.
By their numbers in this assay, from the lowest: compounds 3, 1 and 2 (each within the scatter of the next).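

On the saturated ring carbon, 1H-pyrrol-2-yl in place of furan-2-yl gives a number 3.4 percentage points lower from compound 1 to compound 3 (within the scatter) in this assay as the first step read at this position. Exchanging the ring oxygen of furan-2-yl for the ring nitrogen of 1H-pyrrol-2-yl, with its hydrogen-bond donor, therefore gives no change separable from the scatter. No measurement at hand bears on this result.

From the compounds shown here alone, whether phenyl, a carboxylic acid or an amine on this carbon would give a step beyond the scatter stays open. Also open, going by these compounds, is whether this exchange would read the same with the other substituents of compound 2.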